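A Pentyloxy Chain in Place of Hexyl

The source may hold more compounds than are shown below. What is called first, only, known or untested is meant among the compounds shown, and "the series" means these compounds.

Measured in a physicochemical assay for solubility, read by HPLC, at pH 7.4; a lower number here means a less soluble compound, a higher number a more soluble compound:
- compound 1 `CCCCCOCc1cc(=O)c2cc([N+](=O)[O-])ccc2[nH]1`: 15000 nM
- compound 2 `CCCCCCCc1[nH]c2ccc([N+](=O)[O-])cc2c(=O)c1C(=O)OCC`: 5000 nM

Compound 2 gives the lower number of the two, and its gap to compound 1 lies beyond the scatter. Compound 3 `CCCCCOCc1[nH]c2ccc([N+](=O)[O-])cc2c(=O)c1C(=O)OCC` follows from compound 2 by one change pentyloxy in place of hexyl on a saturated chain carbon bound to an aromatic carbon. Going by the values given here, no measured pair shows this change. Among the compounds with values here, the only pointer is compound 1, which also carries pentyloxy and gives 15000 nM, though its core differs. A modest rise in this assay is therefore expected, and it may stay within the scatter. The expected change is a 1.8-fold higher number from compound 2 to compound 3 (0.26 log units; within the scatter). For compound 3 the estimated value is 9000 nM, with an expected range of 3500 nM to 22000 nM.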

Compound 3, solubility: 15000 nM
Beside the measured number, compound 3's estimate is 1.7-fold (0.22 log units) below it, and the stated range covers the measured number.
By their numbers in this assay, from the lowest: compound 2; then compounds 1 and 3 (each within the scatter of the next).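

Pentyloxy in place of hexyl on a saturated chain carbon bound to an aromatic carbon gives a 3.0-fold higher number from compound 2 to compound 3 (0.48 log units; beyond the scatter) in this assay and is the first measured reading of this change at this position. With pentyloxy present, ethoxycarbonyl in place of hydrogen on an aromatic carbon gives no change at the digits printed from compound 1 to compound 3 (within the scatter) in this assay and leaves the two compounds level. No measurement at hand offers a reason for either step.

As far as these compounds go, whether an amine, a carboxylic acid or a longer chain at this chain carbon would move the number remains open. So does whether ethoxycarbonyl would behave the same way alongside hexyl.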